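The compounds below may be only part of what the source reports. "The series", "measured", "known", "first", "only" and "open" are said of these compounds alone.

Compound 1 `O=C(NCc1ccc(S(=O)(=O)c2ccccc2)cc1)N1CCc2ccncc2C1` gives 115000 nM
Compound 2 `O=C(NCc1ccc(S(=O)(=O)c2cc(F)cc(F)c2)cc1)N1Cc2ccncc2C1` gives 16000 nM

In a physicochemical assay for solubility, in phosphate buffer, with a stated time of 24 h, at pH 7.4, tested at 100 uM (a higher number here means a more soluble compound, a lower number a less soluble compound), compound 2 (16000 nM) has the lower of the two numbers, and the gap to compound 1 (115000 nM) lies beyond the scatter. These two compounds differ in more than one place, so their gap cannot be pinned on any single change.

Compound 3 `O=C(NCc1ccc(S(=O)(=O)C2CCCOC2)cc1)N1Cc2ccncc2C1` has not yet been measured. It matches compound 2 except for one swap: oxan-3-yl in place of 3,5-difluorophenyl on a sulfonyl sulfur is the whole change. Within the data shown here, no measured pair shows this swap alone, so any forecast is uncertain. Among the measured compounds shown here, the only guide is compound 1 (115000 nM), which shows that a related structure can read far higher than compound 2. A rise beyond the scatter is therefore expected, with the estimated move being a 5.0-fold higher number from compound 2 to compound 3 (0.70 log units; beyond the scatter) in this assay as the working figure. Compound 3 is estimated at 80000 nM with an expected range from 32000 nM to 160000 nM as its likely span.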

Compound 3, solubility: 208000 nM
Estimate against measurement, compound 3: 2.6-fold (0.41 log units) below; measured number above the stated range.
By their numbers in this assay, from the lowest: compound 2; then compounds 1 and 3 (each within the scatter of the next).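

In this assay, oxan-3-yl in place of 3,5-difluorophenyl on a sulfonyl sulfur gives a 13-fold higher number from compound 2 to compound 3 (1.11 log units; beyond the scatter) in a large step. Among these compounds, this is the first comparison here in which only one place differs, so this position can now be tied to a large change in the read-out. The swap still alters several things at once, removing an aromatic carbon ring and two fluorines and adding a non-aromatic ring with one oxygen, and no measurement at hand says why the number moves.

From the compounds shown here alone, it remains open whether the move follows the loss of the aromatic ring or the arrival of the ring oxygen, and cyclohexyl at this place would help separate the two. Going by these compounds, how an amine-bearing ring such as piperidin-4-yl or a carboxylic acid would read here also stays unknown.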